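Swapping difluoromethyl for methyl on the aryl ether oxygen

This account rests on a few compounds, and the source may have more. Where it says the series, first, only, none or still open, it means among the compounds named here.

Measured compounds:
compound 1 `FC(F)Oc1ccccc1C1Cc2nccn2C1` gives 75%
compound 2 `COc1ccc(C2Cc3nccn3C2)cc1` gives 27%
compound 3 `c1ccc(C2CCc3nccn3C2)cc1` gives 68%

Of the compounds shown here, three sharing a core have been tested in a functional assay on CHO cells for agonist activity at Alpha-1A adrenergic receptor (Homo sapiens), read by FLIPR and calcium flux; on this read-out lower numbers stand for smaller maximal responses and higher numbers for larger maximal responses. Compound 1 shows the highest of the three numbers, with 75%. Compound 3 comes close, and its 68% sits within the usual scatter of compound 1, so the two cannot be told apart. Compound 2 lies far lower, with 27%, a gap that is clearly beyond the scatter.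

The unmeasured compound 4 `COc1ccccc1C1Cc2nccn2C1` differs from compound 1 in a single place: methyl in place of difluoromethyl on an oxygen on an aromatic ring. Going by the values given here, no pair of measured compounds shows exactly this exchange, so the expected size of the step in this assay rests on the broader picture. Compound 4 carries a methoxy group, as does compound 2, which gives 27%, while compound 1 with its difluoromethoxy gives 75%, which suggests that the smaller group may come with a lower maximal response. A step of a number 20 percentage points lower from compound 1 to compound 4 (beyond the scatter) is therefore expected for compound 4, downward but not necessarily all the way to the level of compound 2. The estimate for compound 4 in this assay is 55%, within a range from 30% to 80%.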

Compound 4, largest response reached (Emax), in percent of the reference or control that the assay uses: 82%
Compound 4: the middle estimate sits 27 percentage points below what was measured; measured number outside the range, above it.
By their numbers in this assay, from the lowest: compound 2; then compounds 3, 1 and 4 (each within the scatter of the next, the first and the last beyond it).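

In this assay, going by these compounds alone, exchanging difluoromethyl for methyl on an oxygen on an aromatic ring gives a number 7 percentage points higher from compound 1 to compound 4 (within the scatter), the first direct reading of a single change in this set, and it does not tell the two compounds apart. At this place, the maximal response stays within the usual scatter whether the group is difluoromethoxy or methoxy, so the two fluorine atoms and the larger group they belong to make no measurable difference in this one pair. Nothing shown here explains why these two groups give responses that cannot be told apart.

Going by these compounds, whether a longer chain such as ethyl, a trifluoromethyl group or a free hydroxyl on the aromatic ring would give a similar maximal response at this place remains open. A single pair also cannot say whether the same exchange would give a similar step on other compounds with the shared core, or how much compound is needed to reach these responses, since this read-out reports only the largest response reached.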